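This account rests on a few compounds, and the source may have more. Where it says the series, first, only, none or still open, it means among the compounds named here.

Measured so far in a functional assay on OVCAR-5 cells (Homo sapiens) for inhibition, read by CCK-8 assay, with a stated time of 72 h, tested at 1 uM (on this read-out higher numbers stand for more inhibition of growth at the one concentration tested and lower numbers for less inhibition of growth), are three compounds
compound 1 `CN(C)C(=O)c1cc2cnc(Nc3ccc(NC(=O)C4(C(=O)Nc5ccc(F)cc5)CC4)cc3)nc2n1C1CCCC1` gives 65.4%
compound 2 `CN(C)C(=O)c1cc2cnc(Nc3ccc(NC(=O)C4(C(=O)Nc5ccc(Cl)cc5)CC4)cc3)nc2n1C1CCCC1` gives 8.1%
compound 3 `CN(C)C(=O)c1cc2cnc(Nc3ccc(NC(=O)C4(C(=O)Nc5cccc(F)c5)CC4)cc3)nc2n1C1CCCC1` gives 26.3%

Compound 1 stands highest of the three, and the other two lie beyond the scatter from it. Compound 4 `CN(C)C(=O)c1cc2cnc(Nc3ccc(NC(=O)C4(C(=O)Nc5ccc(F)cc5)CC4)cc3F)nc2n1C1CCCC1` departs from compound 1 at one place only. The change is fluoro in place of hydrogen on an aromatic carbon in words fluoro in place of hydrogen on an aromatic carbon, ortho to a large group and meta to a large group.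

Going by the values given here, no measured step makes this same change, and all three steps concern a different part of the molecule. Chloro in place of fluoro gave a number 57.3 percentage points lower from compound 1 to compound 2 (beyond the scatter) as a large step. Moving to 3-fluorophenyl in place of 4-fluorophenyl gave a number 39.1 percentage points lower from compound 1 to compound 3 (beyond the scatter) as another large step, while a number 18.2 percentage points higher from compound 2 to compound 3 (beyond the scatter) was modest. These steps show that single-place changes can move the numbers widely among these three compounds, but they do not fix a direction for the new fluoro. All the same, a moderate downward step is expected in this assay from the top position of compound 1 at 65.4% within this small set. The estimated step is a number 15.4 percentage points lower from compound 1 to compound 4 (beyond the scatter) with considerable uncertainty. For compound 4 the estimated value is 50% with a range from 20% to 78% expected.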

Compound 4, percent growth inhibition at one concentration: -0.9%
The estimate for compound 4 lay 50.9 percentage points above the measured number; measured number below the stated range.
By their numbers in this assay, from the lowest: compounds 4 and 2 (each within the scatter of the next); then compound 3; then compound 1.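

In this assay the fluoro placed on this aromatic carbon, ortho to a large group and meta to a large group, gave a number 66.3 percentage points lower from compound 1 to compound 4 (beyond the scatter) and is thus a large step beyond the scatter. The earlier steps shown here all concerned the fluorophenyl group on the amide-type nitrogen, whereas this one shows that the activity of compound 1 also depends strongly on the ring carrying the other amide, where a change of just one heavy atom with no ring, donor, acceptor or net charge was enough. Compound 4 gives -0.9% at the one concentration tested, so this change leaves no growth inhibition to read, and nothing available here explains why this small change has so large an effect.

With only one substituent at this position, the compounds shown cannot tell whether the loss belongs to fluoro itself or to any group on this carbon, such as a methyl group, a methoxy group or an amine. They also leave open whether fluoro on another carbon of the same ring would behave alike, and whether compound 4 would inhibit growth at a higher concentration.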